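Enone Double Bond Geometry in a Diyne Series

The source may hold more compounds than are shown below. What is called first, only, known or untested is meant among the compounds shown, and "the series" means these compounds.

For the measured compounds named here, compound 2 `CCCCCCCC#CC#C/C=C\C(C)=O` is one of two compounds tested so far in a functional assay on SK-MEL-2 cells (Homo sapiens) for cytotoxicity; a lower number here means that less compound is needed, a higher number that more compound is needed for the effect. In this assay, going by the values given here, compound 2 gives 42.6 ug/mL, the only actual number the study has produced. Compound 1 `CCCCCCCC#CC#CC1=CC(=O)NCCC1` reaches only a limit in this assay, where compound 1 gives > 50 ug/mL. Among the compounds with values here, compound 2 thus stands as the sole measured value, while the other compound sits at the limit of > 50 ug/mL in this assay, at which 1 of the 2 values shown sits.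

Compound 3 `CCCCCCCC#CC#C/C=C/C(C)=O` has not yet been tested in this assay. It differs from compound 2 as follows: the two compounds have the same atoms and bonds and differ only in configuration as drawn: 1 of 1 stereo elements differ; a double bond is drawn Z in compound 2 and E in compound 3. Within the data shown here, no step between two measured compounds exists, so no measured change of configuration guides the expectation. With the same atoms and bonds, the step in this assay is expected to be no larger than the usual scatter, in no particular direction. Compound 3 is therefore estimated at 40 ug/mL, with a range from 20 ug/mL to 80 ug/mL. This corresponds to an expected step of a 1.1-fold lower number from compound 2 to compound 3 (0.03 log units; within the scatter).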

Compound 3, concentration for half-maximal effect: 1.4 ug/mL
Compound 3: middle estimate off by 29-fold (1.46 log units), on the high side; measured number outside the range, below it.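

In this assay, the double bond of the enone turns out to be a place where configuration alone carries a large effect: going from Z to E gives a 30-fold lower number from compound 2 to compound 3 (1.48 log units; beyond the scatter). The earlier compounds shown here offered no measured step at all, and this pair now shows that the drawn geometry of this one double bond is enough to separate two compounds well beyond the scatter. The gap can be laid on that double bond alone because nothing else distinguishes the pair: the fact that compounds 2 and 3 differ only in the configuration as drawn

The compounds shown leave open whether the preference for the E form persists when the end of the chain carries a carboxylic acid instead of the ketone, or when a longer chain stands at the far side of the diyne. They also leave open whether it extends beyond this one cell line.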